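Sulfonamide thiourea quinolines: antiproliferative read-out notes

The source may report more compounds than this note shows. Statements on the series, on what has been measured and on what is new or still open speak of the compounds shown alone.

Measured compounds:
compound 1 `N=C(N)NS(=O)(=O)c1ccc(N/C(S)=N\c2ccnc3cc(C(F)(F)F)ccc23)cc1` — "not active" (no number reported) (no number reported)
compound 2 `Cc1noc(NS(=O)(=O)c2ccc(N/C(S)=N\c3ccnc4cc(C(F)(F)F)ccc34)cc2)c1C` — 27900 nM
compound 3 `O=S(=O)(Nc1ncccn1)c1ccc(N/C(S)=N\c2ccnc3cc(C(F)(F)F)ccc23)cc1` — 45200 nM

In a functional assay on MDA-MB-231 cells (Homo sapiens) for antiproliferative activity, read by sulforhodamine B assay, with a stated time of 48 h (on this read-out lower numbers stand for stronger inhibition and higher numbers for weaker inhibition), compound 1 gives "not active" (no number reported), so it carries no number. Compound 2 gives 27900 nM and compound 3 gives 45200 nM. For the measured compounds named here, compound 3 stands at the highest of the two numbers, but its only neighbour is within the scatter: a 1.6-fold higher number from compound 2 to compound 3 (0.21 log units; within the scatter).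

Compound 4 `COc1ncnc(NS(=O)(=O)c2ccc(N/C(S)=N\c3ccnc4cc(C(F)(F)F)ccc34)cc2)c1OC` differs from compound 3 in one place: 5,6-dimethoxypyrimidin-4-yl in place of pyrimidin-2-yl on a sulfonamide nitrogen. Going by the values given here, no measured step covers this change directly. Among the compounds with values here, the one step that bears on it, an exchange of the group on the same sulfonamide nitrogen, reads a 1.6-fold higher number from compound 2 to compound 3 (0.21 log units; within the scatter) and is within the scatter. Within the data shown here, on that basis no step beyond the scatter is expected in this assay for compound 4, in either direction, with the single earlier exchange as the sole guide.

Compound 4 is therefore expected to give about 40000 nM, with a range of 15000 nM to 110000 nM, which would mean an estimated step of a 1.1-fold lower number from compound 3 to compound 4 (0.05 log units; within the scatter).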

Compound 4, half-maximal inhibitory concentration: 83000 nM
For compound 4 the middle estimate is 2.1-fold (0.32 log units) below the measured one; measured number inside the range.
By their numbers in this assay, from the lowest: compounds 2, 3 and 4 (each within the scatter of the next, the first and the last beyond it).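

In this assay this position on the sulfonamide nitrogen now gives a step beyond the scatter, though only a modest one: a 3.0-fold higher number from compound 2 to compound 4 (0.47 log units; beyond the scatter), on replacing 3,4-dimethyl-1,2-oxazol-5-yl with 5,6-dimethoxypyrimidin-4-yl. The exchange of pyrimidin-2-yl for 5,6-dimethoxypyrimidin-4-yl stays within the scatter, at a 1.8-fold higher number from compound 3 to compound 4 (0.26 log units; within the scatter), so the group's influence appears only between compound 2 and compound 4, and compound 3 separates from neither. Nothing measured here accounts for the step between compound 2 and compound 4.

Steps to compound 1 cannot be read, as it carries no number. Open questions are whether a single methoxy group on the pyrimidine ring gives the same reading as the 5,6-dimethoxy pattern, and how an acetyl group or a longer alkyl chain on this nitrogen would read.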